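Aryl Hydrazone Thiosemicarbazones: A Nitro for a Methoxy

A few compounds are considered here, and "the series" means these few. Any claim that something is new, unique, unknown or untested is made for them only; others in the source may bear on it.

Measured so far:
Compound 1 `CC1=CC[C@@H]([C@@](C)(O)CCCC(C)(C)NC=S)CC1`: > 100000 nM
Compound 2 `CC1=CC[C@@H]([C@@](C)(O)CCCC(C)(C)NC(=S)NN)CC1`: > 100000 nM
Compound 3 `COc1ccc(/C=N\NC(=S)NC(C)(C)CCC[C@](C)(O)[C@@H]2CC=C(C)CC2)cc1`: 48500 nM

Of the compounds shown here, three built on the shared core have been tested in a functional assay on UACC-62 cells (Homo sapiens) for cytotoxicity, read by sulforhodamine B assay; a lower number here means that less compound is tolerated, a higher number that more compound is tolerated. Compound 1 gives only a limit there, > 100000 nM, and not a number. Compound 2 likewise gives only a limit, > 100000 nM. Between them lies a step that the two limits leave unreadable from compound 1 to compound 2, which the two limits leave unreadable. Among the measured compounds shown here, compound 3 is the one compound with an actual number in this assay, 48500 nM, reached by an at least 2.0-fold lower number from compound 2 to compound 3 (0.31 log units; beyond the scatter). Compound 3 thus stands alone with a number, while the other two sit at the limit of > 100000 nM in this assay, at which 2 of the 3 values shown sit.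

Compound 4 `CC1=CC[C@@H]([C@@](C)(O)CCCC(C)(C)NC(=S)N/N=C\c2ccccc2[N+](=O)[O-])CC1` is not yet measured. It differs from compound 3 by 2-nitrophenyl in place of 4-methoxyphenyl on a carbon with a double bond to nitrogen. For the measured compounds named here, no measured step swaps one aryl group for another; the only step that touches this part of the molecule is the one from compound 2 to compound 3, in which the whole aryl hydrazone arrives, and that step shows the aryl hydrazone itself bringing the number down. Going by the values given here, with no step that distinguishes one aryl from another, compound 4 is expected to stay near where compound 3 sits, a step of a 1.1-fold lower number from compound 3 to compound 4 (0.03 log units; within the scatter). The estimate for compound 4 in this assay is 45000 nM, with a range from 15000 nM to 100000 nM.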

Compound 4, concentration lethal to 50% of the cells: 49300 nM
Compound 4: the middle estimate sits 1.1-fold (0.04 log units) below what was measured; the range from low to high includes it.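

In this assay, the exchange of 4-methoxyphenyl for 2-nitrophenyl on a carbon with a double bond to nitrogen comes out as a 1.0-fold higher number from compound 3 to compound 4 (0.01 log units; within the scatter). Among the compounds shown here, this is the only measured step that replaces one aryl group with another, and it shows that this position carries two quite different aryl groups with no readable difference in the number, which the step that brought in the whole aryl hydrazone could not show. Compound 3 and compound 4 both give actual numbers, while the two compounds without an aryl group stay at a limit: the limit of > 100000 nM in this assay, at which 2 of the 4 values shown sit.

For the compounds shown here, the one step changes the substituent and its place on the ring together, so the two cannot be told apart from it. Also open, on these data alone, is whether an unsubstituted phenyl, a pyridine ring, or an amine or a carboxylic acid on the ring would leave the number where compound 3 and compound 4 stand, or move it clearly away.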